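The source may report more compounds than this note shows. Statements on the series, on what has been measured and on what is new or still open speak of the compounds shown alone.

Of the compounds shown here, three of one shared core have been measured. Compound 1 `Cc1cccc(C)c1-c1cc2c(cn1)ncn2-c1ccc(OC(F)F)cc1` gives 980 nM in a functional assay on HL-60 cells (Homo sapiens) for activation, read by flow cytometry, with a stated time of 4 days; on this read-out lower numbers stand for an effect already at smaller amounts and higher numbers for an effect only at larger amounts of compound. Compound 2 `Fc1ccc(-c2cc3c(cn2)ncn3-c2ccc(OC(F)F)cc2)c(Cl)c1` gives 90 nM in this assay, and compound 3 `CCc1ccccc1-c1cc2c(cn1)ncn2-c1ccc(OC(F)F)cc1` gives 2900 nM. Compound 2 holds the lowest number of the three: the change from compound 1 to compound 2 brought an 11-fold lower number from compound 1 to compound 2 (1.04 log units; beyond the scatter), and going on to compound 3 gave a 32-fold higher number from compound 2 to compound 3 (1.51 log units; beyond the scatter), while compound 1 to compound 3 gave a 3.0-fold higher number from compound 1 to compound 3 (0.47 log units; beyond the scatter). So the attached aryl group, carrying small halogen or alkyl groups, sets the activity over a wide span.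

Compound 4 `CCCOc1cc(F)ccc1-c1cc2c(cn1)ncn2-c1ccc(OC(F)F)cc1` differs from compound 2 in this way: propoxy in place of chloro on an aromatic carbon. For the measured compounds named here, no measured step exchanges a chloro for a propoxy group, so none bears directly on it. The nearest guide is the move from compound 1 to compound 3, where a longer alkyl group on that aryl ring gave a higher number, and the wide spread of all three steps shows that this aryl ring is sensitive to what sits on it. A propoxy group is larger than the chloro it replaces, so a higher number than compound 2 is expected, with the step from compound 2 to compound 4 estimated at a 4.4-fold higher number from compound 2 to compound 4 (0.65 log units; beyond the scatter). Compound 4 is therefore expected to give about 400 nM in this assay, within a range of 80 nM to 2000 nM.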

Compound 4, half-maximal effective concentration: 58 nM
The estimate for compound 4 lay 6.9-fold (0.84 log units) above the measured number; measured number outside the range, below it.
By their numbers in this assay, from the lowest: compounds 4 and 2 (each within the scatter of the next); then compound 1; then compound 3.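

In this assay, putting propoxy in place of chloro gave a 1.6-fold lower number from compound 2 to compound 4 (0.19 log units; within the scatter), so compounds 2 and 4 stand level even though 4 heavy atoms, one of them oxygen, replace 1 heavy atom on the aromatic carbon. For the compounds shown here, the earlier steps on this aryl ring, such as a 32-fold higher number from compound 2 to compound 3 (1.51 log units; beyond the scatter), showed only that changes to the ring can move the number a long way, whereas this pair shows that a much larger group at this one place need not move it beyond the scatter. Nothing in the data given explains why these two different groups give matching numbers.

Going by these compounds, it remains open whether the oxygen or the carbon chain matters more: a plain propyl group at this place would separate the two, while a methoxy group or a longer butoxy chain would show how far the tolerance extends. On these data alone, compounds 2 and 4 also share the fluoro group, so it is unknown how propoxy would behave without that group, or how a propoxy chain ending in an amine would behave.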